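Removing a methyl from an inactive methylamino compound

The source may hold more compounds than are shown below. What is called first, only, known or untested is meant among the compounds shown, and "the series" means these compounds.

Compound 1 `CCCCCC(CCO)n1cnc2c(Cl)ncnc21`, compound 2 `CCCCCC(CCO)n1cnc2c(OC)ncnc21` and compound 3 `CCCCCC(CCO)n1cnc2c(NC)ncnc21` share one core and differ only in the chloro, methoxy or methylamino group on an aromatic carbon. All three were tested in a functional assay on SW480 cells (Homo sapiens) for antiproliferative activity, read by MTT assay, with a stated time of 48 h; a higher number here means a weaker inhibitor, a lower number a stronger inhibitor. In this assay compound 1 gives > 50000 nM, which is a limit and not a number. Compound 2 likewise gives a limit, > 50000 nM. Compound 3 also gives only a limit, > 50000 nM. The whole series therefore rests at a single point: the limit of > 50000 nM in this assay, at which 3 of the 3 values shown sit.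

Compound 4 `CCCCCC(CCO)n1cnc2c(N)ncnc21` departs from compound 3 through one change, hydrogen in place of methyl on a nitrogen on an aromatic ring, so that methylamino becomes amino: hydrogen in place of methyl on a nitrogen on an aromatic ring. The measured steps that bear on this group are a step that the two limits leave unreadable from compound 1 to compound 3 and a step that the two limits leave unreadable from compound 2 to compound 3. Neither has a size that can be carried over to the new change, so no step beyond the scatter is expected in this assay, and no direction is favoured. The expected step is a number no higher from compound 3 to compound 4 (the limit leaves the size open). Compound 4 is estimated at 50000 nM. Its expected range runs from 25000 nM to 100000 nM, and a report of only a limit is the likeliest outcome.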

Compound 4, half-maximal inhibitory concentration: > 50000 nM
Compound 4 gave a limit, no number; the forecaster's own chance of this, stated with the estimate: 85%; the middle value lies on the limit itself.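

In this assay compound 4, like compound 1, compound 2 and compound 3, gives only a limit, so the steps to compound 4 from each of the other three cannot be read. The compounds shown leave open how the four truly compare, and whether any group at this place on the shared core would yield a measurable value.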